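Trading 2-Methylpyridin-3-yl for 3-Methylphenyl: Expected Lipophilicity

The compounds below may be only part of what the source reports. "The series", "measured", "known", "first", "only" and "open" are said of these compounds alone.

Of the compounds shown here, three have been measured in a physicochemical assay for lipophilicity, read by HPLC, at pH 7.5; a lower number here means a more polar compound, a higher number a more lipophilic compound. Compound 1 `CC[C@@H](Nc1c(C#N)c(-c2ccc(-c3cccnc3C)cc2)nc2cnccc12)C(N)=O` gives 1.9. Compound 2 `N#Cc1c(-c2ccc(Br)cc2)nc2cnccc2c1NCC(N)=O` gives 1.9, matching compound 1 within the scatter. Compound 3 `CCOc1ccccc1-c1ccc(-c2nc3cnccc3c(NC(C(N)=O)C3CC3)c2C#N)cc1` gives 3, higher than compounds 1 and 2 beyond the scatter, so compound 1 sits level with compound 2 at the low end of the three. Compound 4 `CC[C@@H](Nc1c(C#N)c(-c2ccc(-c3cccc(C)c3)cc2)nc2cnccc12)C(N)=O` is not yet measured and differs from compound 1 in one place: 3-methylphenyl in place of 2-methylpyridin-3-yl on an aromatic carbon. Going by the values given here, no pair of measured compounds isolates this change; compound 3 carries a carbon-only ring but differs elsewhere too. The step is expected to run upward and beyond the scatter, a number 0.90 log units higher from compound 1 to compound 4 (beyond the scatter). Compound 3 with its carbon-only ring gives 3, which supports that expectation. Compound 4 is estimated at 2.8, within 2.3 to 3.3.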

Compound 4, distribution coefficient: 3
For compound 4 the middle estimate is 0.20 log units below the measured one; low and high end bracket the measured number.
By their numbers in this assay, from the lowest: compounds 1 and 2 (each within the scatter of the next); then compounds 3 and 4 (each within the scatter of the next).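

In this assay, going by these compounds alone, this swap on an aromatic carbon, para to a large group, gives the first reading of the change on its own: a number 1.10 log units higher from compound 1 to compound 4 (beyond the scatter) between compounds that differ in this one place. The two groups hold the same count of heavy atoms, but the entering one is carbon only and has no hydrogen-bond acceptor. Nothing measured here gives a cause for the step. The group names show that the methyl changes place too, so the nitrogen swap and the methyl shift remain unseparated. On these data alone, how an amine or a carboxylic acid on this ring would read also remains open.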